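Carbamate analogues in the writhing test: repositioning the nitro group

The source may report more compounds than this note shows. Statements on the series, on what has been measured and on what is new or still open speak of the compounds shown alone.

Compound 1 `NC(=O)OC(CCN1CCN(c2ccccc2)CC1)c1cccc(Cl)c1`: 59%
Compound 2 `CC(C)(C)c1ccc(C(CCN2CCN(c3ccccc3)CC2)OC(N)=O)cc1`: 62%
Compound 3 `NC(=O)OC(CCN1CCN(c2ccccc2)CC1)c1cccc([N+](=O)[O-])c1`: 48%

In a functional assay on the whole organism for inhibition, with Mus musculus as the target, in the writhing test, with a stated time of 1 h, at a dose of 10 mg/kg by the oral route (a lower number here means less inhibition, a higher number more inhibition at the dose given (going by the name of the read-out)), compound 3 gives 48%, the lowest of the three numbers; compound 1 gives 59% and compound 2 gives 62%, both beyond the scatter above it. For the measured compounds named here, the one measured step, a number 11 percentage points lower from compound 1 to compound 3 (beyond the scatter), concerns nitro in place of chloro on an aromatic carbon and was modest.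

Compound 4 `NC(=O)OC(CCN1CCN(c2ccccc2)CC1)c1ccc([N+](=O)[O-])cc1` differs from compound 3 in one place: 4-nitrophenyl in place of 3-nitrophenyl on a saturated chain carbon bound to an oxygen next to a carbonyl group and a saturated chain carbon. Going by the values given here, no measured step moves a group around the aromatic ring, so the step from compound 1 to compound 3 bears only loosely on this change. Compound 4 is therefore expected to stay close to compound 3, with an estimated step of a number 2 percentage points higher from compound 3 to compound 4 (within the scatter), not beyond the scatter. The estimate for compound 4 is 50%, within 35% to 65%.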

Compound 4, a percentage reported as inhibition, in the whole organism at one dose (the size of the read-out at that dose, not a potency): 91.2%
Compound 4: middle estimate off by 41.2 percentage points, on the low side; the whole stated range lies below it.
By their numbers in this assay, from the lowest: compound 3; then compounds 1 and 2 (each within the scatter of the next); then compound 4.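

Moving the nitro group, with the same atoms joined differently, gives a number 43.2 percentage points higher from compound 3 to compound 4 (beyond the scatter), so at this position the place of the nitro group on the ring counts for far more than the earlier compounds could show. The 4-nitrophenyl group also goes well past the other two substituted rings, with a number 32.2 percentage points higher from compound 1 to compound 4 (beyond the scatter) and a number 29.2 percentage points higher from compound 2 to compound 4 (beyond the scatter). Nothing at hand accounts for the size of this shift.

The compounds shown leave open whether this high number belongs to the nitro group itself. An amine or a carboxylic acid in the place the nitro group holds in compound 4 could test that.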